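The source may hold more compounds than are shown below. What is called first, only, known or untested is meant among the compounds shown, and "the series" means these compounds.

Measured compounds in a functional assay on B16 cells (Mus musculus) for cytotoxicity, read by sulforhodamine B assay, with a stated time of 72 h; on this read-out lower numbers stand for stronger inhibition and higher numbers for weaker inhibition:
compound 1 `OCC#CCSc1cnc2ccccc2c1[Se]CC#CCBr`, 4.6 ug/mL
compound 2 `C[Se]c1c(SCC#CCO)cnc2ccccc12`, 5.8 ug/mL
compound 3 `C#CCSc1cnc2ccccc2c1[Se]CC#CCBr`, 4.2 ug/mL

Compound 3 gives the lowest of the three numbers, but its neighbours sit close: compound 1 is the nearest and compound 2 the furthest, and both gaps fall within the scatter, so no order among the three can be read from these numbers.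

The unmeasured compound 4 `C#CCSc1cnc2ccccc2c1SCC#CCO` differs from compound 3 in one place: a group of 6 heavy atoms (4 carbon, 1 oxygen, 1 sulfur; no ring) in place of a group of 6 heavy atoms (4 carbon, 1 selenium, 1 bromine; no ring), on an aromatic carbon.

Two steps are known. a 1.3-fold higher number from compound 1 to compound 2 (0.10 log units; within the scatter) touches the same side of the core, shortening the chain on the selenium atom, and changed little. a 1.1-fold lower number from compound 1 to compound 3 (0.04 log units; within the scatter) altered the chain on the sulfur atom and also changed little. Neither step exchanges selenium for sulfur or brings in the hydroxyl group at this place, so the present change is only partly covered; what is covered points to no step beyond the scatter in this assay.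

Compound 4 is therefore expected to give 5 ug/mL, range 2.5 ug/mL to 10 ug/mL, that is an expected 1.2-fold higher number from compound 3 to compound 4 (0.08 log units; within the scatter).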

Compound 4, concentration for 50% inhibition: 54.7 ug/mL
Beside the measured number, compound 4's estimate is 11-fold (1.04 log units) below it; the measured number lies above the stated range.
By their numbers in this assay, from the lowest: compounds 3, 1 and 2 (each within the scatter of the next); then compound 4.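

In this assay, among the compounds shown here, the aromatic carbon opposite the ring nitrogen is the first place where a change gives a step beyond the scatter: a 13-fold higher number from compound 3 to compound 4 (1.11 log units; beyond the scatter). The chain on selenium had already been replaced by a methyl group with selenium kept, and that step stayed within the scatter: a 1.3-fold higher number from compound 1 to compound 2 (0.10 log units; within the scatter); the large step therefore appears only where selenium and the bromine-bearing chain leave together and sulfur and a hydroxyl-bearing chain enter. Nothing among the data accounts for the size of this step.

The selenium-to-sulfur exchange and the bromine-to-hydroxyl exchange remain unseparated, so either one alone could carry the step, or both together. Also open, as far as these compounds go, is how a methylsulfanyl group or an amine on this carbon would read in this assay.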